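Amine substituent exchange on the shared core

A few compounds are considered here, and "the series" means these few. Any claim that something is new, unique, unknown or untested is made for them only; others in the source may bear on it.

Of the compounds shown here, two have been measured in an assay on cells for displacement of a labelled ligand from corticotropin-releasing factor receptor 1 (Homo sapiens), with a stated time of 100 min; on this read-out higher numbers stand for weaker inhibition and lower numbers for stronger inhibition. Compound 1 `C=C(C)CN(CC)Cc1c(C(F)(F)F)nc2n(-c3c(C)cc(C)cc3C)c(Cl)cn12` gives 67 nM, and compound 2 `Cc1cc(C)c(-n2c(Cl)cn3c(CN(CCC4CC4)CCC(F)(F)F)c(C(F)(F)F)nc23)c(C)c1` gives 110 nM. Compound 1 holds the lower of the two numbers, but its gap to compound 2 lies within the scatter, so no order between them can be drawn.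

Compound 3 `CCCN(Cc1ccccc1)Cc1c(C(F)(F)F)nc2n(-c3c(C)cc(C)cc3C)c(Cl)cn12` is not yet measured. Against compound 1 it differs by benzyl(propyl)amino in place of ethyl(2-methylprop-2-en-1-yl)amino on a saturated chain carbon bound to an aromatic carbon, an exchange of the amine substituent attached to the shared core. Within the data shown here, no measured pair in the set shows an exchange of this kind, so the size of the step has no precedent here. The step is estimated at a 1.3-fold higher number from compound 1 to compound 3 (0.13 log units; within the scatter), expected to be small, if anything towards a higher number, and likely within the scatter. On this basis compound 3 is expected to give about 90 nM, with a range from 30 nM to 300 nM.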

Compound 3, inhibition constant: 170 nM
Compound 3: middle estimate off by 1.9-fold (0.28 log units), on the low side; the measured number falls inside the stated range.
By their numbers in this assay, from the lowest: compounds 1, 2 and 3 (each within the scatter of the next, the first and the last beyond it).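

Among these compounds, replacing ethyl(2-methylprop-2-en-1-yl)amino with benzyl(propyl)amino on a saturated chain carbon bound to an aromatic carbon gives a 2.5-fold higher number from compound 1 to compound 3 (0.40 log units; beyond the scatter), the first step that lies beyond the scatter. The amine substituent at this place therefore does register in this assay, although the step is modest and a substituent holding a six-membered aromatic ring still leaves compound 3 at 170 nM. Nothing on hand ties this step to any measured property of either substituent.

The exchange alters the aromatic ring, the double bond and the alkyl chain at once, so their separate contributions remain unresolved. Benzyl(ethyl)amino, which would keep the ethyl chain of compound 1 and add the benzyl group of compound 3, and dipropylamino, which would carry no aromatic ring, remain open as tests of this.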